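Hydroxy for hydrogen on the isopropyl chain of compound 2

A few compounds are considered here, and "the series" means these few. Any claim that something is new, unique, unknown or untested is made for them only; others in the source may bear on it.

Two compounds of the series carry measurements in an assay on isolated protein for inhibition of mitogen-activated protein kinase kinase kinase 6 (Homo sapiens); on this read-out higher numbers stand for weaker inhibition and lower numbers for stronger inhibition. Compound 1 `CC(C)n1cnnc1-c1cccc(NC(=O)Nc2ccccn2)n1` gives 1090 nM. Compound 2 `CC(C)n1cnnc1-c1cccc(NC(=O)Nc2ncc3ccccc3n2)n1` gives 2910 nM, the higher of the two numbers, and the gap to compound 1 is beyond the scatter. No single-point change connects these two, so only their two values can be read side by side.

Compound 3 `C[C@H](CO)n1cnnc1-c1cccc(NC(=O)Nc2ncc3ccccc3n2)n1` has not yet been measured. It differs from compound 2 by hydroxy in place of hydrogen on a saturated chain carbon, two bonds along the chain from an aromatic nitrogen. For the measured compounds named here, no measured pair isolates this change, so nothing in the data calibrates its effect; the two measured compounds differ elsewhere entirely.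

Without a precedent, the step of a 1.5-fold lower number from compound 2 to compound 3 (0.16 log units; within the scatter) is expected to stay within the usual scatter, if anything leaning towards a slightly lower number. The estimate for compound 3 in this assay is 2000 nM, with a range from 700 nM to 6000 nM. A measurement of compound 3 would be the first point on this change within the series.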

Compound 3, half-maximal inhibitory concentration: 7170 nM
The estimate for compound 3 lay 3.6-fold (0.55 log units) below the measured number; the measured number lies above the stated range.
By their numbers in this assay, from the lowest: compound 1; then compound 2; then compound 3.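

In this assay, hydroxy in place of hydrogen on a saturated chain carbon, two bonds along the chain from an aromatic nitrogen, gives a 2.5-fold higher number from compound 2 to compound 3 (0.39 log units; beyond the scatter), so the isopropyl to 1-(hydroxymethyl)ethyl exchange is not neutral on this core and moves the read-out towards weaker inhibition. Compound 1 and compound 2 both carry isopropyl and could say nothing about this position, which now proves sensitive to the addition of a single oxygen atom, although the step is only modest in size. No measurement at hand accounts for this step.

Going by these compounds, it remains open whether the loss belongs to the hydroxy itself or would also appear with a methoxy, an amine, a carboxylic acid or a longer chain such as 2-hydroxyethyl at this place, and whether the mirror-image form of the 1-(hydroxymethyl)ethyl group behaves in the same way. On these data alone, it is also open whether the same exchange on the core of compound 1 would give a step of similar direction and size.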